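The source may report more compounds than this note shows. Statements on the series, on what has been measured and on what is new or still open speak of the compounds shown alone.

In an assay on MDA-MB-231 cells for binding affinity to C-X-C chemokine receptor type 4 (Homo sapiens), read by fluorescence and microscopy, with stated times of 10 min and 30 min (on this read-out higher numbers stand for an effect only at larger amounts of compound and lower numbers for an effect already at smaller amounts), compound 1 `CCN(CC)Cc1ccc(S(=O)(=O)NCc2ccc(CNC(=O)c3ccc(F)cc3)cc2)cc1` gives 1 nM. Compound 2 `Cc1ccc(S(=O)(=O)NCc2ccc(CNC(=O)c3ccc(F)nc3)cc2)cc1` returns only a limit of the assay, > 1000 nM, so no number is known for it. Compound 3 `O=C(NCc1ccc(CNS(=O)(=O)c2cccc3ccccc23)cc1)c1ccc(F)cc1` gives 1000 nM, the highest of the two numbers shown in this assay; its gap to compound 1 is far beyond the usual scatter of repeat measurements.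

Compound 4 `Cc1cccc(S(=O)(=O)NCc2ccc(CNC(=O)c3ccc(F)cc3)cc2)c1` differs from compound 3 in one place: 3-methylphenyl in place of naphthalen-1-yl on a sulfonyl sulfur. Among the measured compounds shown here, of the compounds measured so far, none pairs this smaller aromatic group with the rest of the core of compound 3, so the data give no direct guide to the size of this step in this assay. For the measured compounds named here, the one compound with a methylphenyl group on the sulfonyl sulfur, compound 2, also carries a different amide part, and its reading is only a limit. On that basis the step from compound 3 to compound 4 is expected to be a 1.4-fold lower number from compound 3 to compound 4 (0.15 log units; within the scatter), within the scatter. Compound 4 is therefore estimated at 700 nM, with a range from 150 nM to 3000 nM.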

Compound 4, effective concentration (reported as EC, without a stated level of effect): 1 nM
Estimate against measurement, compound 4: 700-fold (2.85 log units) above; measured number below the stated range.
By their numbers in this assay, from the lowest: compounds 1 and 4 (each within the scatter of the next); then compound 3.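

In this assay, replacing naphthalen-1-yl with 3-methylphenyl on a sulfonyl sulfur gives a 1000-fold lower number from compound 3 to compound 4 (3.00 log units; beyond the scatter). Among the compounds shown here, with the rest of the molecule unchanged, this one group separates an effect at small amounts of compound from an effect only at large amounts, and no earlier pair differing in one place could show that. The number for compound 3 also stands at the edge of what the assay reports: the limit of > 1000 nM in this assay, at which 1 of the 4 values shown sits.

Going by these compounds, it remains open whether the step follows from losing the second aromatic ring or from having the methyl group, and a plain phenyl group would help separate the two. On these data alone, how a carboxylic acid in place of that methyl group would read at this position also remains unknown.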